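The source may hold more compounds than are shown below. What is called first, only, known or untested is meant among the compounds shown, and "the series" means these compounds.

Measured so far in this series:

compound 1, `CN1[C@@H]2c3[nH]c4ccccc4c3C[C@H]1[C@H](C#N)N1[C@@H](CNC(=O)c3cc4ccccc4s3)c3[nH]c4ccccc4c3C[C@@H]21` — 300 nM
compound 2, `CN1[C@@H]2c3[nH]c4ccccc4c3C[C@H]1[C@H](C#N)N1[C@@H](CNC(=O)c3cc4ccccc4o3)c3[nH]c4ccccc4c3C[C@@H]21` — 280 nM

Both numbers come from a functional assay on HepG2 cells (Homo sapiens) for cytotoxicity, read by MTT assay, with a stated time of 72 h; on this read-out lower numbers stand for stronger inhibition and higher numbers for weaker inhibition. Compound 2 holds the lowest of the two numbers; its nearest neighbour is compound 1, and the two values lie within the scatter of each other, so no order between them can be read. Among the compounds with values here, the one measured step, a 1.1-fold lower number from compound 1 to compound 2 (0.03 log units; within the scatter), exchanged the hetero atom of the five-membered ring on the carbonyl carbon and left the read-out essentially where it was.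

Compound 3, `CN1[C@@H]2c3[nH]c4ccccc4c3C[C@H]1[C@H](C#N)N1[C@@H](CNC(=O)c3cc4ccccc4[nH]3)c3[nH]c4ccccc4c3C[C@@H]21`, is not yet measured. It differs from compound 2 in one place: 1H-indol-2-yl in place of 1-benzofuran-2-yl on a carbonyl carbon. Within the data shown here, the same position has been varied once before, in the step of a 1.1-fold lower number from compound 1 to compound 2 (0.03 log units; within the scatter), which stayed within the scatter; that is the only measured step bearing on this change. One measured step on a single position is a thin basis, and the new group brings a hydrogen-bond donor where the earlier two brought an acceptor, so the range is kept wide. Compound 3 is therefore expected to give 300 nM in this assay, within a range of 130 nM to 700 nM. The step this estimate means, a 1.1-fold higher number from compound 2 to compound 3 (0.03 log units; within the scatter), is expected to be none beyond the scatter.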

Compound 3, half-maximal inhibitory concentration: 440 nM
Compound 3: middle estimate off by 1.5-fold (0.17 log units), on the low side; low and high end bracket the measured number.
By their numbers in this assay, from the lowest: compounds 2, 1 and 3 (each within the scatter of the next).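

Working notes on the amide position, in this assay: with 1H-indol-2-yl on the carbonyl carbon, both new steps stay within the scatter, a 1.6-fold higher number from compound 2 to compound 3 (0.20 log units; within the scatter) and a 1.5-fold higher number from compound 1 to compound 3 (0.17 log units; within the scatter). The series now holds three fused aromatic groups at this place, differing in the hetero atom of the five-membered ring, and none of the three steps among them can be read as a real difference. What the earlier pair could not show is that the hydrogen-bond donor counted on 1H-indol-2-yl, and absent from 1-benzofuran-2-yl, brings no step beyond the scatter in this read-out. No measurement at hand offers an explanation for these results.

Open, on these data alone, is whether the read-out stays this flat when the fused aromatic group gives way to something of a different kind, such as a plain phenyl, a saturated cyclohexyl, an aminoalkyl chain or a carboxylic acid. Also open, as far as these compounds go, is whether substituents such as fluoro or methoxy on the six-membered ring of these groups would separate the compounds, and whether their closeness holds outside this assay.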